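The source may report more compounds than this note shows. Statements on the series, on what has been measured and on what is new or still open speak of the compounds shown alone.

Values so far in an ADME assay on HepG2 cells (Homo sapiens) for cytotoxicity, read by MTT assay, with a stated time of 72 h (on this read-out higher numbers stand for lower toxicity in this test and lower numbers for higher toxicity in this test), for the series:

- Compound 1 `Cc1nc2c(Sc3ccc(Cl)cc3)cc(Cl)cn2c1[N+](=O)[O-]` gives > 7800 nM as a limit.
- Compound 2 `O=[N+]([O-])c1c(CS(=O)(=O)c2ccccc2)nc2c(Nc3ccc(Cl)cc3)cc(Cl)cn12` gives > 3900 nM as a limit.
- Compound 3 `CSCc1nc2c(Br)cc(Cl)cn2c1[N+](=O)[O-]` gives > 15600 nM as a limit.

Compound 3 therefore has no number in this assay, and neither of the other two compounds has one. Compound 4 `Cc1nc2c(Br)cc(Cl)cn2c1[N+](=O)[O-]` differs from compound 3 by hydrogen in place of methylsulfanyl on a saturated chain carbon bound to an aromatic carbon in one place, with hydrogen in place of methylsulfanyl on a saturated chain carbon bound to an aromatic carbon. For the measured compounds named here, no measured pair differs in only one place. The methyl of compound 4 also occurs in compound 1, which shows only a limit at > 7800 nM in this series. The expected step of a number no higher from compound 3 to compound 4 (the limit leaves the size open) is none beyond the usual scatter, in either direction. The estimate for compound 4 is 15600 nM with an expected range of 6000 nM to 40000 nM in this assay here.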

Compound 4, half-maximal cytotoxic concentration: > 125000 nM
Compound 4 ended at the assay's limit (the forecaster's own chance of this, stated with the estimate: 85%); at least 8.0-fold (0.90 log units) between middle value and limit.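

Compound 3 and compound 4 both stand only as limits in this assay, so no step can be read between them. The compounds shown leave open what size of change, if any, (methylsulfanyl)methyl to methyl brings.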